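Aryl swap on the ring nitrogen: outlook for compound 3

The compounds below may be only part of what the source reports. "The series", "measured", "known", "first", "only" and "open" are said of these compounds alone.

Measured so far in a functional assay on A549 cells (Homo sapiens) for antiproliferative activity, read by CCK-8 assay, with a stated time of 72 h; on this read-out higher numbers stand for weaker inhibition and lower numbers for stronger inhibition:
- compound 1, `CC1=NN(c2ccc(C)cc2)C(=O)C12C=CC(=O)C=C2c1ccccc1`, gives 46300 nM
- compound 2, `CC1=NN(c2cccc(Cl)c2)C(=O)C12C=CC(=O)C=C2c1ccccc1`, gives 18800 nM

Within the data shown here, compound 2 holds the lowest of the two numbers in this assay; its only neighbour is compound 1, and the step of a 2.5-fold lower number from compound 1 to compound 2 (0.39 log units; beyond the scatter) is the single measured step. That step changes two things at once, the group on the phenyl and where it sits, so it cannot be split into a part for the chlorine and a part for its position.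

Compound 3, `CC1=NN(c2ccc(Cl)cc2)C(=O)C12C=CC(=O)C=C2c1ccccc1`, keeps every atom of compound 2 and differs only in how the atoms are joined: 4-chlorophenyl in place of 3-chlorophenyl on an amide-type nitrogen in a ring. Among the measured compounds shown here, no measured pair moves a chlorine from one position of the phenyl to another, so there is no direct precedent. For the measured compounds named here, the one step at hand, from compound 1 to compound 2, is modest, which suggests that changes on this phenyl shift this assay only to a limited degree. Compound 3 is therefore expected to stay close to compound 2, with a step of a 1.3-fold higher number from compound 2 to compound 3 (0.11 log units; within the scatter) that need not exceed the scatter. The estimate for compound 3 is 24000 nM, expected between 9000 nM and 65000 nM.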

Compound 3, half-maximal inhibitory concentration: > 100000 nM
Compound 3: a limit, no number; the forecaster's own chance of this, stated with the estimate: 10%; middle value at least 4.1-fold (0.61 log units) away from the limit.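

For compound 3 the read-out in this assay is a limit and not a number: the limit of > 100000 nM in this assay, at which 1 of the 3 values shown sits.

With the atoms unchanged, 4-chlorophenyl in place of 3-chlorophenyl gives an at least 5.3-fold higher number from compound 2 to compound 3 (0.72 log units; beyond the scatter), so this phenyl is sensitive to where the chlorine sits, which the earlier pair could not show because it changed the group and its position together. With the position held, chloro in place of methyl gives an at least 2.1-fold higher number from compound 1 to compound 3 (0.33 log units; beyond the scatter), so chlorine does not lower the number on this phenyl in itself: compound 2 lies below compound 1, while compound 3 lies above it.

The limit leaves the true size of both new steps open, and these compounds do not tell why the position matters so much. Also open, on these data alone, are how an unsubstituted phenyl compares with these three, and whether a methoxy group or an amine on the phenyl shows the same dependence on position as the chlorine does.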